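The source may hold more compounds than are shown below. What is called first, only, known or untested is meant among the compounds shown, and "the series" means these compounds.

Compound 1, `COc1ccc([N+](=O)[O-])cc1CSc1nc2cc(NC(=O)NC(C)(C)C)ccc2n1C1CC1`, gives 860 nM in an assay on isolated protein for inhibition of Gonadotropin-releasing hormone receptor (Rattus norvegicus); a higher number here means a weaker inhibitor, a lower number a stronger inhibitor.
Compound 2, `CCCn1c(SCc2cc([N+](=O)[O-])ccc2OC)nc2cc(NC(=O)NC(C)(C)C)ccc21`, gives 120 nM in this assay.
Compound 3, `COc1ccc([N+](=O)[O-])cc1CSc1nc2cc(NC(=O)NC(C)(C)C)ccc2n1Cc1ccccc1`, gives 160 nM in this assay.

Compound 2 has the lowest number of the three, though compound 3 sits within the scatter of it; only compound 1 stands clearly apart, as a 7.2-fold lower number from compound 1 to compound 2 (0.86 log units; beyond the scatter) shows. Compound 4, `COc1ccc([N+](=O)[O-])cc1CSc1nc2cc(NC(=O)NC(C)(C)C)ccc2n1-c1ccccc1`, is reached from compound 2 by a single change: phenyl in place of propyl on an aromatic nitrogen. For the measured compounds named here, two measured steps bear on it. a 1.3-fold higher number from compound 2 to compound 3 (0.12 log units; within the scatter) stayed within the scatter, so swapping a phenyl for an ethyl on the chain carbon bound to the ring nitrogen left the number essentially unmoved. a 7.2-fold lower number from compound 1 to compound 2 (0.86 log units; beyond the scatter) and a 5.4-fold lower number from compound 1 to compound 3 (0.73 log units; beyond the scatter) show that the cyclopropyl group gives a clearly higher number than either propyl or benzyl. A phenyl placed directly on the ring nitrogen, with no chain carbon between, has no measured precedent among these compounds, so the expectation rests on the nearest analogues alone. The step expected from this change, a 2.5-fold higher number from compound 2 to compound 4 (0.40 log units; beyond the scatter), is a modest rise, with wide uncertainty. Compound 4 is therefore expected to give 300 nM in this assay, within an estimated range of 100 nM to 1000 nM.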

Compound 4, half-maximal inhibitory concentration: > 2600 nM
Compound 4 gave a limit, no number; the forecaster's own chance of this, stated with the estimate: 5%; middle value at least 8.6-fold (0.93 log units) from the limit.
By their numbers in this assay, from the lowest: compounds 2 and 3 (each within the scatter of the next); then compound 1. At a limit, above all of these: compound 4.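

Compound 4 gives no number in this assay, only a limit: the limit of > 2600 nM in this assay, at which 1 of the 4 values shown sits.

Phenyl on the aromatic nitrogen costs far more than any earlier change at this position, with an at least 21-fold higher number from compound 2 to compound 4 (1.33 log units; beyond the scatter) and an at least 16-fold higher number from compound 3 to compound 4 (1.21 log units; beyond the scatter), so the same aromatic ring that is compatible with a low number when a saturated chain carbon carries it is not compatible with one when it sits on the nitrogen itself. Cyclopropyl no longer marks the top of the range, given an at least 3.0-fold higher number from compound 1 to compound 4 (0.48 log units; beyond the scatter), and among the four compounds the two with a ring atom on the aromatic nitrogen give the higher numbers, with none going against this.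

Still open, going by these compounds, is whether this rise belongs to any ring placed on the nitrogen or to phenyl in particular, and a cyclohexyl or a pyridyl group there would speak to that. Also open, on these data alone, is how far the number holds as the group grows, which a longer chain such as butyl or a phenethyl group would test.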